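Removing the hydroxypropyl chain from a ring nitrogen

This account rests on a few compounds, and the source may have more. Where it says the series, first, only, none or still open, it means among the compounds named here.

The measured compounds, each with its result in an assay on 32D cells for inhibition of interleukin-15 (Mus musculus), read by resazurin assay, with stated times of 30 min and 2.5 days, in the presence of a further agent that is not named here; on this read-out lower numbers stand for stronger inhibition and higher numbers for weaker inhibition:
Compound 1, `Cn1c(Cc2nn(CCC3OCCO3)c(=O)c3ccccc23)nnc1SCC(=O)Nc1ccc(Cl)cc1Cl`. In this assay compound 1 gives > 30000 nM, which is a limit of the assay and not a number.
Compound 2, `Cn1c(Cc2nn(CCCO[Si](C)(C)C(C)(C)C)c(=O)c3ccccc23)nnc1SCCCCCCCC(=O)Nc1ccc(Cl)cc1Cl`. In this assay compound 2 gives > 30000 nM, again a limit rather than a number.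
Compound 3, `Cn1c(Cc2nn(CCCO)c(=O)c3ccccc23)nnc1SCCCCCCCC(=O)Nc1ccc(Cl)cc1Cl`. In this assay compound 3 gives > 30000 nM, once more a limit of the assay.

Compound 3 therefore stands at the limit, with no number of its own, and the same holds for every compound measured here, as the limit of > 30000 nM in this assay, at which 3 of the 3 values shown sit, shows. Among the compounds with values here, the one step between measured compounds that differ in a single place, a step that the two limits leave unreadable from compound 2 to compound 3, cannot be read, since both ends of it are limits.

The next compound, compound 4, is `Cn1c(Cc2n[nH]c(=O)c3ccccc23)nnc1SCCCCCCCC(=O)Nc1ccc(Cl)cc1Cl`. It differs from compound 3 in one place: hydrogen in place of 3-hydroxypropyl on an aromatic nitrogen. Within the data shown here, no measured step bears on this change, and no measured value gives a number to move from. The expectation is that compound 4, like the others, sits at the limit, so the step that the limit leaves unreadable from compound 3 to compound 4 is estimated as none beyond the scatter. For compound 4 the estimate in this assay is 40000 nM, with a range from 10000 nM to 150000 nM.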

Compound 4, half-maximal inhibitory concentration: > 30000 nM
Compound 4: a limit, no number (the forecaster's own chance of this, stated with the estimate: 85%); the middle value lies beyond the limit too.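

In this assay compound 4 gives > 30000 nM, which is a limit and not a number. The steps to compound 4 from compound 2 and from compound 3 cannot be read, and all the compounds stand at the same point: the limit of > 30000 nM in this assay, at which 4 of the 4 values shown sit.

The compounds shown leave open which change to the structure, if any, would give a measurable value in this assay.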